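Acylhydrazone series: removing the aryl chloro substituent

The source may hold more compounds than are shown below. What is called first, only, known or untested is meant among the compounds shown, and "the series" means these compounds.

Measured compounds:
- compound 1, `COc1ccc(OC)c(/C=C/c2nnc(Nc3ccc(Cl)cc3)o2)c1`: 15900 nM
- compound 2, `COc1ccc(OC)c(/C=C/C(=O)N/N=C/c2ccc(Cl)cc2)c1`: 115 nM

Two compounds have been run in a functional assay on OVCAR-3 cells (Homo sapiens) for antiproliferative activity, read by sulforhodamine B assay, with a stated time of 48 h; a lower number here means a stronger inhibitor of growth, a higher number a weaker inhibitor of growth. Compound 1 gives 15900 nM in this assay. Compound 2 gives 115 nM in this assay, the lowest of the two numbers; the gap to compound 1 is far beyond the scatter. Among the compounds with values here, no single-point step between measured compounds exists, so compound 2 is the only anchor for the next step.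

Compound 3, `COc1ccc(OC)c(/C=C/C(=O)N/N=C/c2ccccc2)c1`, remains to be measured in this assay. Its difference from compound 2 is hydrogen in place of chloro on an aromatic carbon; one bond further out this reads as 4-chlorophenyl to phenyl, hydrogen in place of chloro on an aromatic carbon, para to a large group. The step from compound 2 to compound 3 is expected to be small, at most a modest rise, possibly none beyond the scatter, as a 2.6-fold higher number from compound 2 to compound 3 (0.42 log units; beyond the scatter). Compound 3 is therefore estimated at 300 nM in this assay, within a range of 80 nM to 1200 nM.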

Compound 3, concentration for total growth inhibition: > 100000 nM
Compound 3 gave a limit, no number; the forecaster's own chance of this, stated with the estimate: 3%; middle value at least 330-fold (2.52 log units) from the limit.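

In this assay, within the data shown here, the 4-chlorophenyl to phenyl change gives the first single-place comparison, and it is large: an at least 860-fold higher number from compound 2 to compound 3 (2.93 log units; beyond the scatter). Among these compounds, compound 1 and compound 2 differ in more than one place, so only this pair shows that growth inhibition by compound 2 depends heavily on the chloro, a single heavy atom on an aromatic carbon, para to a large group. Compound 3 gives > 100000 nM, a limit and not a number, so the step has no known upper end: the limit of > 100000 nM in this assay, at which 1 of the 3 values shown sits.

Whether this dependence is specific to chloro stays open, since the compounds shown carry no bromo, methyl or amine at this place. Also open, on these data alone, is whether removing the chloro would have a similar effect on the core of compound 1.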